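A few compounds are considered here, and "the series" means these few. Any claim that something is new, unique, unknown or untested is made for them only; others in the source may bear on it.

For the measured compounds named here, compound 1 `NCCCCN(C[C@H]1Cc2ncccc2CN1)[C@H]1CCCc2cccnc21` is one of only two compounds measured in an assay on isolated protein for inhibition of Alpha-2C adrenergic receptor (Homo sapiens); a lower number here means a stronger inhibitor, a higher number a weaker inhibitor. In this assay compound 1 gives 13000 nM. Compound 2 `NCCCCN(C[C@H]1Cc2cccnc2CN1)[C@H]1CCCc2cccnc21` shares the same core, and in this assay compound 2 gives 30000 nM. Of these two numbers compound 1 stands lowest, and its gap to compound 2 lies beyond the usual scatter of the measurement.

Compound 3 `CN(CCCCN(C[C@H]1Cc2ncccc2CN1)[C@H]1CCCc2cccnc21)C1CCC(F)(F)CC1` has not yet been measured. It differs from compound 1 by a group of 10 heavy atoms (7 carbon, 1 nitrogen, 2 fluorine; one six-membered non-aromatic ring of carbon only) in place of one nitrogen atom, on a saturated chain carbon, four bonds along the chain from an amine nitrogen. Going by the values given here, no measured pair shows a change of this kind, so the size of the step cannot be read from any measured pair and has to be estimated from compound 1 alone. For compound 3 the estimated step is a 4.3-fold lower number from compound 1 to compound 3 (0.64 log units; beyond the scatter), expected to run toward a lower number, with a wide margin because nothing measured here supports it directly. For compound 3 the estimated value in this assay is 3000 nM, with a range from 500 nM to 15000 nM.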

Compound 3, half-maximal inhibitory concentration: > 30000 nM
Compound 3: only a limit was reported; the forecaster's own chance of this, stated with the estimate: 5%; middle value at least 10-fold (1.00 log units) from the limit.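

Compound 1 and compound 2 carry the same amino group, on a saturated chain carbon, four bonds along the chain from an amine nitrogen, so only compound 3 brings a change at this place into view: in this assay the larger group with its six-membered non-aromatic ring of carbon only gives an at least 2.3-fold higher number from compound 1 to compound 3 (0.36 log units; beyond the scatter) and so points toward weaker inhibition rather than stronger. Compound 3 is reported only as a limit, > 30000 nM in this case and not a number, which fixes the direction of the step but not its full size. This single change at this place therefore brought no gain in inhibition, and that reading rests on one limit: the limit of > 30000 nM in this assay, at which 1 of the 3 values shown sits.

On these data alone, whether the ring, the 2 fluorine atoms or the loss of the amino group's hydrogen-bond donor drives this step stays open, since all three change together in compound 3. Also open, as far as these compounds go, is how a smaller replacement, such as a methylamino or hydroxyl group, or a longer chain still ending in an amino group, would behave at this place.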